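The compounds below may be only part of what the source reports. "The series", "measured", "known", "first", "only" and "open" are said of these compounds alone.

Measured in a functional assay on HCT-116 cells (Homo sapiens) for antiproliferative activity, read by MTT assay, with a stated time of 72 h; on this read-out lower numbers stand for stronger inhibition and higher numbers for weaker inhibition:
- Compound 1 `COc1ccc(OCCCON2C(N)=NC(N)=NC23CCOCC3)cc1`: 1500 nM
- Compound 2 `NC1=NC2(CCOCC2)N(OCCCOc2ccc(Br)cc2)C(N)=N1`: 320 nM

Compound 2 holds the lower of the two numbers, at 320 nM. Compound 3 `CC(C)(C)c1ccc(OCCCON2C(N)=NC(N)=NC23CCOCC3)cc1` has not yet been measured and differs from compound 2 in one place, with tert-butyl in place of bromo on an aromatic carbon.

Among the measured compounds shown here, only one measured step bears on this place: a 4.7-fold lower number from compound 1 to compound 2 (0.67 log units; beyond the scatter), a modest step that came with bromo in place of methoxy. It shows that a change here can move the number in this assay. However, no measured compound carries tert-butyl, so the data do not fix a direction for the new change. No clear step beyond the scatter is therefore expected, and the estimate means a 1.1-fold higher number from compound 2 to compound 3 (0.04 log units; within the scatter). For compound 3 the estimated value is 350 nM, with an expected range of 110 nM to 1100 nM.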

Compound 3, half-maximal inhibitory concentration: 1610 nM
Compound 3: the middle estimate sits 4.6-fold (0.66 log units) below what was measured; measured number outside the range, above it.
By their numbers in this assay, from the lowest: compound 2; then compounds 1 and 3 (each within the scatter of the next).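

In this assay the new result shows that this aromatic carbon does not simply favour any replacement of methoxy: tert-butyl in place of bromo gives a 5.0-fold higher number from compound 2 to compound 3 (0.70 log units; beyond the scatter) and so runs against the direction of a 4.7-fold lower number from compound 1 to compound 2 (0.67 log units; beyond the scatter). Tert-butyl in place of methoxy gives a 1.1-fold higher number from compound 1 to compound 3 (0.03 log units; within the scatter), so these two groups cannot be told apart here, and among the three compounds only compound 2, with bromo, stands apart from the others. Nothing available explains why this one group differs from the other two.

From the compounds shown here alone, whether the lower number is particular to bromo or is shared by chloro or fluoro remains open. Going by these compounds, it is equally open how an amine or a carboxylic acid on this aromatic carbon would behave, or whether the bromo effect would hold with a longer chain in place of the present linker.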